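Aryl amide variation and the expected value for compound 4

A few compounds are considered here, and "the series" means these few. Any claim that something is new, unique, unknown or untested is made for them only; others in the source may bear on it.

Compound 1 `O=C(CSc1nc(Nc2ccccc2)c2ccccc2n1)Nc1ccccc1F` gives 10700 nM in a functional assay on MGC-803 cells (Homo sapiens) for inhibition, read by MTT assay, with a stated time of 72 h; a higher number here means a weaker inhibitor, a lower number a stronger inhibitor.
Compound 2 `O=C(CSc1nc(Nc2ccccc2)c2ccccc2n1)Nc1cccc(Cl)c1` gives 14300 nM in this assay.
Compound 3 `O=C(CSc1nc(Nc2ccccc2)c2ccccc2n1)Nc1ccc([N+](=O)[O-])cc1` returns only an assay limit, > 50000 nM in this assay.

Of the two compounds with a number, compound 2 has the higher one, although the step of a 1.3-fold higher number from compound 1 to compound 2 (0.13 log units; within the scatter) lies within the scatter. For compound 3 the result is a limit (the limit of > 50000 nM in this assay, at which 1 of the 3 values shown sits). Compound 4 `O=C(CSc1nc(Nc2ccccc2)c2ccccc2n1)Nc1ccc(C(F)(F)F)cc1` differs from compound 2 in one place: 4-(trifluoromethyl)phenyl in place of 3-chlorophenyl on an amide-type nitrogen. The measured steps that bear on this change both exchange the phenyl on the amide-type nitrogen: an at least 4.6-fold higher number from compound 1 to compound 3 (0.66 log units; beyond the scatter) and an at least 3.4-fold higher number from compound 2 to compound 3 (0.54 log units; beyond the scatter), each at least modest and toward a weaker inhibitor. Since 4-(trifluoromethyl)phenyl is not 4-nitrophenyl, a smaller step toward a higher number is expected: a 1.5-fold higher number from compound 2 to compound 4 (0.19 log units; within the scatter). Compound 4 is therefore estimated at 22000 nM, with a range from 9000 nM to 50000 nM.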

Compound 4, half-maximal inhibitory concentration: 8670 nM
For compound 4 the middle estimate is 2.5-fold (0.40 log units) above the measured one; the whole stated range lies above it.
By their numbers in this assay, from the lowest: compounds 4, 1 and 2 (each within the scatter of the next). At a limit, above all of these: compound 3.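

Trifluoromethyl in place of nitro on an aromatic carbon gives an at least 5.7-fold lower number from compound 3 to compound 4 (0.76 log units; beyond the scatter), so the weak result of compound 3 does not carry over to 4-(trifluoromethyl)phenyl on the amide-type nitrogen. Against the other two aryl amides the change stays small, with a 1.6-fold lower number from compound 2 to compound 4 (0.22 log units; within the scatter) and a 1.2-fold lower number from compound 1 to compound 4 (0.09 log units; within the scatter), so compounds 1, 2 and 4 cannot be separated in this assay. The step from compound 3 rests on a limit, not a number: the limit of > 50000 nM in this assay, at which 1 of the 4 values shown sits.

The compounds shown leave open whether an amine or a carboxylic acid on this phenyl would side with compound 4 or with compound 3. Also open, from the compounds shown here alone, is what a longer chain in place of the phenyl would do.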